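The source may report more compounds than this note shows. Statements on the series, on what has been measured and on what is new or still open speak of the compounds shown alone.

Measured in a functional assay on HCT-116 cells (Homo sapiens) for antiproliferative activity; a higher number here means a weaker inhibitor, a lower number a stronger inhibitor: compound 1 `Cn1ccc2ccc3c(c4c(c5c6cccc7c6n(c35)CC(CO)C7)C(=O)NC4=O)c21` gives 680 nM; compound 2 `COc1ccc2c(c1)[nH]c1c2c2c(c3c4cccc5c4n(c13)CC(CO)C5)C(=O)NC2=O` gives 1830 nM; compound 3 `O=C1NC(=O)c2c1c1c3ccccc3[nH]c1c1c2c2cccc3c2n1CC(CO)CC3` gives 540 nM.

Compound 2 stands highest of the three numbers. Compound 1 is nearest, compound 3 furthest, and both gaps lie beyond the scatter, so compound 2 is the weakest inhibitor of the measured set. Compound 4 `O=C1NC(=O)c2c1c1c3ccc(Br)cc3[nH]c1c1c2c2cccc3c2n1CC(CO)C3` is not yet measured. It differs from compound 2 by bromo in place of methoxy on an aromatic carbon. Among the compounds with values here, no measured pair shows this exchange, so no step of this kind is known. A lowering of the number, small to moderate and not clearly beyond the scatter, is expected in this assay. The step expected is a 1.8-fold lower number from compound 2 to compound 4 (0.26 log units; within the scatter). Compound 4 is estimated at 1000 nM, with a range from 350 nM to 2900 nM.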

Compound 4, half-maximal inhibitory concentration in the HCT-116 assay: 500 nM
Compound 4: the middle estimate sits 2.0-fold (0.30 log units) above what was measured, within the range that was stated.
By their numbers in the HCT-116 assay, from the lowest: compounds 4, 3 and 1 (each within the scatter of the next); then compound 2.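

Within the data shown here, on this aromatic carbon the substituent matters: in the HCT-116 assay, compound 2 gives 1830 nM and compound 4 gives 500 nM and bromo in place of methoxy gives a 3.7-fold lower number from compound 2 to compound 4 (0.56 log units; beyond the scatter), the first readable single-place step. In a physicochemical assay for solubility (a higher number here means a more soluble compound, a lower number a less soluble compound), compound 2 gives 490 ug/mL and compound 4 gives 830 ug/mL and the same exchange gives a 1.7-fold higher number from compound 2 to compound 4 (0.23 log units; within the scatter), so the step in the HCT-116 assay comes with no separation in the physicochemical assay outside the scatter. No supporting data bear on why the number moves.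

From the compounds shown here alone, whether the step belongs to bromo itself or to the departure of methoxy remains open. An amine or a chloro on this same carbon would help separate the two.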